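A hexyloxy swap at the assay's limit

The compounds below may be only part of what the source reports. "The series", "measured", "known", "first", "only" and "open" are said of these compounds alone.

Measured in an ADME assay on MOLT-3 cells (Homo sapiens) for cytotoxicity, with a stated time of 7 days; on this read-out lower numbers stand for higher toxicity in this test and higher numbers for lower toxicity in this test:
Compound 1 `CC(C)Sc1nc(N)nc2c1ncn2/C=C1/CC1(CO)CO`: > 20000 nM (a limit)
Compound 2 `Nc1nc(SC2CCCC2)c2ncn(/C=C3/CC3(CO)CO)c2n1`: > 20000 nM (a limit)

Compound 2 stands at > 20000 nM in this assay and this is a limit, not a number. The picture so far is the limit of > 20000 nM in this assay, at which 2 of the 2 values shown sit, and nothing finer. Compound 3 `CCCCCCOc1nc(N)nc2c1ncn2/C=C1/CC1(CO)CO` differs from compound 2 as follows: hexyloxy in place of cyclopentylsulfanyl on an aromatic carbon (hexyloxy in place of cyclopentylsulfanyl). Within the data shown here, the only measured step is a step that the two limits leave unreadable from compound 1 to compound 2 and it offers no size to carry over. No change beyond the scatter is expected in either direction, so the estimated a number no higher from compound 2 to compound 3 (the limit leaves the size open) stays small. Compound 3 is expected at about 20000 nM (estimated range 7000 nM to 40000 nM).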

Compound 3, half-maximal cytotoxic concentration: > 20000 nM
Compound 3 was reported as a limit (the forecaster's own chance of this, stated with the estimate: 70%); the middle value lies on the limit itself.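

Among these compounds, no step between compound 1, compound 2 and compound 3 can be read, as each value is a limit and not a number: the limit of > 20000 nM in this assay, at which 3 of the 3 values shown sit. Still open, from the compounds shown here alone, is how far each compound lies beyond that limit, and whether these swapped groups differ in cytotoxicity at all.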